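The compounds below may be only part of what the source reports. "The series", "measured", "known", "first", "only" and "open" are said of these compounds alone.

Measured compounds:
- compound 1 `Cc1cccc(Nc2nc(-c3ccncc3-c3ccncc3)cs2)c1`: 13800 nM; 13800 nM (2 entries)
- compound 2 `Cc1cccc(Nc2nc(-c3ccncc3Cl)cs2)c1`: 2950 nM
- compound 3 `Cc1cccc(Nc2nc(-c3ccncc3-c3ccc(C(C)C)cc3)cs2)c1`: > 40000 nM; 40700 nM (2 entries)

Notes on the series. The shared core carries an aryl group whose substituent varies. In a functional assay on RCC4 cells (Homo sapiens) for inhibition, read by XTT assay, with a stated time of 4 days (a lower number here means a stronger inhibitor, a higher number a weaker inhibitor), compound 1 gives 13800 nM; 13800 nM (2 entries). In this assay compound 3 gives > 40000 nM; 40700 nM (2 entries). One of the entries of compound 3 is a limit of the assay rather than a number (the several entries of compound 3 in this assay, > 40000 nM; 40700 nM (2 entries)). Compound 2, with chloro at the same position, gives 2950 nM in this assay; among the numbers shown it is the lowest, and two further entries for it carry no single number. The gap between compound 2 and compound 1 lies well beyond the scatter.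

Compound 4 `Cc1cccc(Nc2nc(-c3ccncc3Br)cs2)c1` is not yet measured. It differs from compound 2 by bromo in place of chloro on an aromatic carbon. Going by the values given here, the change is a single-atom halogen swap with no ring, donor or acceptor involved; no measured pair in this set makes the same swap, so its size cannot be read from the data. The expectation is a step of no more than the usual scatter, in either direction, so the estimated step is a 1.1-fold lower number from compound 2 to compound 4 (0.04 log units; within the scatter). Compound 4 is therefore expected to give about 2700 nM, within 1200 nM to 6500 nM, in this assay.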

Compound 4, half-maximal inhibitory concentration: 3980 nM
The estimate for compound 4 lay 1.5-fold (0.17 log units) below the measured number, within the range that was stated.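

In this assay the swap gives a 1.3-fold higher number from compound 2 to compound 4 (0.13 log units; within the scatter), so on this aromatic carbon, ortho to a large group and two atoms from the ring nitrogen, bromo in place of chloro leaves the read-out within the scatter. Going by these compounds alone, until now chloro was the only halogen with a number at this position; with a second one, the lower range of the series no longer rests on compound 2 alone, as compound 4 at 3980 nM also stands numerically well under compound 1 at 13800 nM; 13800 nM (2 entries) in the same assay. No measurement at hand bears on what lies behind this step.

As far as these compounds go, how an amine, a carboxylic acid or a short alkyl chain at this position would compare with chloro and bromo remains open, so the reading for the two halogens cannot yet be extended to other small groups. Also open, from the compounds shown here alone, is whether fluoro or iodo would stay within the scatter of the chloro and bromo pair, or would part from it.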